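A Ring Swap on a Compound Low in Cell Toxicity

The compounds below may be only part of what the source reports. "The series", "measured", "known", "first", "only" and "open" are said of these compounds alone.

Compound 1 `CCN(C)c1nc(Cc2c(F)cccc2F)cc(=O)[nH]1` is the starting point, tested in an ADME assay on MT4 cells (Homo sapiens) for cytotoxicity, read by MTT assay, with a stated time of 4 days; on this read-out higher numbers stand for lower toxicity in this test and lower numbers for higher toxicity in this test. In that test compound 1 gives > 89000 nM, which is a limit of the assay and not an exact number. Compound 2 `O=c1cc(Cc2c(F)cccc2N2CCCC2)nc(N2CCCC2)[nH]1` gives > 73000 nM, and this too is only a limit. Neither compound has an exact value, so no order between them can be read, and compound 1 has no measured neighbour to be ranked against.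

Compound 3 `O=c1cc(Cc2c(F)cccc2F)nc(N2CCCCC2)[nH]1` has not yet been measured. It carries piperidin-1-yl in place of ethyl(methyl)amino on an aromatic carbon of the core of compound 1: piperidin-1-yl in place of ethyl(methyl)amino on an aromatic carbon. Within the data shown here, no measured pair shows what such a change does, so the expectation leans on compound 2, whose result of > 73000 nM is a limit as well. No step beyond the usual scatter is expected in this assay, in either direction. The expected change is an at least 1.1-fold lower number from compound 1 to compound 3 (0.04 log units; that floor lies within the scatter). For compound 3 the estimated value is 80000 nM, with an expected range from 30000 nM to 130000 nM.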

Compound 3, half-maximal cytotoxic concentration: > 82000 nM
Compound 3: only a limit was reported; the forecaster's own chance of this, stated with the estimate: 75%; middle value at least 1.0-fold (0.01 log units) from the limit.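

Compound 3 gives > 82000 nM, which is a limit of the assay and not a number. Compound 1 also has only a limit, and the step from compound 1 to compound 3 cannot be read. The compounds shown leave open at what concentration any of them would harm the cells, and whether piperidin-1-yl in place of ethyl(methyl)amino changes that concentration.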